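A few compounds are considered here, and "the series" means these few. Any claim that something is new, unique, unknown or untested is made for them only; others in the source may bear on it.

Measured so far in a functional assay on B16 cells (Mus musculus) for cytotoxicity, read by MTT assay, with a stated time of 72 h; on this read-out lower numbers stand for stronger inhibition and higher numbers for weaker inhibition:
compound 1 `COc1ccc(-c2cc(=O)c3c(O)cc(OCCCCN4CCN(C)CC4)c(OC)c3o2)cc1` gives 4100 nM
compound 2 `COc1c(OCCCCN2CCN(C)CC2)cc(O)c2c(=O)cc(-c3ccc([N+](=O)[O-])cc3)oc12` gives 2890 nM
compound 3 `O=c1cc(-c2ccccc2)oc2c(OCCCN3CCCC3)c(OCc3ccccc3)cc(O)c12` gives 7980 nM

In this assay compound 3 stands at the upper end of the numbers shown: compound 1 lies within the scatter of it, whereas compound 2 lies beyond it. Compound 4 `CN1CCN(CCCCOc2c(OCc3ccccc3)cc(O)c3c(=O)cc(-c4ccccc4)oc23)CC1` differs from compound 3 by (4-methylpiperazin-1-yl)methyl in place of pyrrolidin-1-yl on a saturated chain carbon, three bonds along the chain from an oxygen on an aromatic ring. Going by the values given here, the one measured step, a 1.4-fold lower number from compound 1 to compound 2 (0.15 log units; within the scatter), concerns a different part of the molecule and does not bear on this change. Compounds 1 and 2 carry the entering group, but they differ from compound 3 elsewhere as well, so their numbers give only a loose hint. The step of a 1.5-fold lower number from compound 3 to compound 4 (0.16 log units; within the scatter) is therefore expected to stay within the scatter. Compound 4 is estimated at 5500 nM, between 2500 nM and 12000 nM.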

Compound 4, half-maximal inhibitory concentration: 2370 nM
Compound 4: middle estimate off by 2.3-fold (0.37 log units), on the high side; the whole stated range lies above it.
By their numbers in this assay, from the lowest: compounds 4, 2, 1 and 3 (each within the scatter of the next, the first and the last beyond it).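

Replacing 3-(pyrrolidin-1-yl)propyl with 4-(4-methylpiperazin-1-yl)butyl in this assay gives a 3.4-fold lower number from compound 3 to compound 4 (0.53 log units; beyond the scatter) and so shows that this chain on the aromatic oxygen is a place where the number moves beyond the scatter. Going by these compounds alone, the one earlier step, a 1.4-fold lower number from compound 1 to compound 2 (0.15 log units; within the scatter) for nitro in place of methoxy, concerned another part of the molecule and stayed within the scatter. Nothing available explains the new step.

The ring and the chain length change together, so these compounds cannot tell which of the two carries the step. A 3-(4-methylpiperazin-1-yl)propyl group would separate them, and a morpholine ring on the same chain remains an open case.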